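The compounds below may be only part of what the source reports. "The series", "measured", "known", "first", "only" and "open" are said of these compounds alone.

Compound 2 `O=C1NC(c2ccccc2)=C([N+](=O)[O-])C(c2ccc(O)cc2)N1` gives 0.035 mg/kg in an in vivo functional assay on the whole organism (heart) with Rattus norvegicus as the target (a lower number here means that less compound is needed, a higher number that more compound is needed for the effect), the lowest of the two numbers measured here; its nearest companion, compound 1 `O=C1NC(c2ccccc2)=C([N+](=O)[O-])C(c2cccs2)N1`, gives 3.5 mg/kg. Compound 3 `O=C1NC(c2ccccc2)=C([N+](=O)[O-])C(c2cccc(F)c2)N1` is compound 2 with 3-fluorophenyl in place of 4-hydroxyphenyl on a saturated ring carbon. Among the compounds with values here, the only measured step touching this saturated ring carbon, a 100-fold lower number from compound 1 to compound 2 (2.00 log units; beyond the scatter), shows that exchanging the group there can shift the dose a great deal, and no measured compound carries a fluorophenyl group. Compound 3 is therefore expected to need a higher dose, a step of a 14-fold higher number from compound 2 to compound 3 (1.15 log units; beyond the scatter). The estimate for compound 3 is 0.5 mg/kg, within 0.05 mg/kg to 5 mg/kg.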

Compound 3, minimum effective dose: 0.00035 mg/kg
Compound 3: the middle estimate sits 1400-fold (3.15 log units) above what was measured; the measured number lies below the stated range.
By their numbers in this assay, from the lowest: compound 3; then compound 2; then compound 1.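

In this assay, the 4-hydroxyphenyl group is not the best group tested at this saturated ring carbon: a 100-fold lower number from compound 2 to compound 3 (2.00 log units; beyond the scatter) shows that a low dose does not depend on the hydrogen-bond donor and acceptor of the group that leaves. Across this one position, a 10000-fold lower number from compound 1 to compound 3 (4.00 log units; beyond the scatter) sets the span seen so far. No supporting evidence is available to explain these steps.

Because the group's substituent and its place on the phenyl ring change together, their contributions remain unseparated. From the compounds shown here alone, a 3-hydroxyphenyl or 4-fluorophenyl group would pull them apart, and whether an amine at either place fits the same trend remains open.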